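Replacing dimethylamino with methyl on the shared core

This account rests on a few compounds, and the source may have more. Where it says the series, first, only, none or still open, it means among the compounds named here.

Compound 1 `CSc1ncnc2c1c(-c1ccoc1)cn2[C@@H]1O[C@H](CO)[C@@H](O)[C@H]1O`: 3250 nM
Compound 2 `CN(C)c1ncnc2c1c(-c1ccoc1)cn2[C@@H]1O[C@H](CO)[C@@H](O)[C@H]1O`: 14900 nM

In a functional assay on K562 cells (Homo sapiens), read by MTT assay, with a stated time of 72 h (a higher number here means a weaker inhibitor, a lower number a stronger inhibitor), compound 2 holds the higher of the two numbers, at 14900 nM. Compound 3 `Cc1ncnc2c1c(-c1ccoc1)cn2[C@@H]1O[C@H](CO)[C@@H](O)[C@H]1O`, not yet measured, has methyl in place of dimethylamino on an aromatic carbon. Going by the values given here, one measured step bears on this change, since it brought in the same dimethylamino group: a 4.6-fold higher number from compound 1 to compound 2 (0.66 log units; beyond the scatter). On these data alone, removing that group is therefore expected to give a lower number, by a step of similar size, though methyl remains untested. The expected change is a 6.0-fold lower number from compound 2 to compound 3 (0.78 log units; beyond the scatter). For compound 3 the estimated value is 2500 nM, within an expected range of 500 nM to 9000 nM.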

Compound 3, half-maximal inhibitory concentration: > 20000 nM
Compound 3 was reported as a limit; the forecaster's own chance of this, stated with the estimate: 3%; middle value at least 8.0-fold (0.90 log units) away from the limit.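

In this assay, compound 3 is reported only as a limit: the limit of > 20000 nM in this assay, at which 1 of the 3 values shown sits. At this position, methyl does not match methylsulfanyl, with an at least 6.1-fold higher number from compound 1 to compound 3 (0.78 log units; beyond the scatter), so of the three groups shown only methylsulfanyl gives a measured number below both others. Against dimethylamino the result is an at least 1.3-fold higher number from compound 2 to compound 3 (0.12 log units; that floor lies within the scatter), a floor that allows no order between methyl and dimethylamino.

On these data alone, how far the true value of compound 3 lies past its limit remains open. Also open, as far as these compounds go, is whether an ethylsulfanyl chain, a methoxy group or a primary amine at this place would behave like methylsulfanyl.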